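The compounds below may be only part of what the source reports. "The series", "measured", "known", "first", "only" and "open" are said of these compounds alone.

In a functional assay on HeLa cells (Homo sapiens) for cytotoxicity, read by MTT assay (on this read-out lower numbers stand for stronger inhibition and higher numbers for weaker inhibition), compound 1 (`COc1cc(CCCCC(C)(C)O)oc(=O)c1C`) gives > 200000 nM, which is a limit of the assay and not a number. Compound 2 (`Cc1c(O)cc(CCCCC(C)C)oc1=O`) gives > 200000 nM, which is likewise a limit. Compound 2 thus gives no number, and it stands with compound 1 at the limit of > 200000 nM in this assay, at which 2 of the 2 values shown sit. Compound 3 (`CC(=O)C(C)CCCCc1cc(O)c(C)c(=O)o1`) carries a single change from compound 2: acetyl in place of methyl on a saturated chain carbon bound to two saturated chain carbons. Among the compounds with values here, no measured pair shows what this change does in this assay, so no step beyond the scatter is expected, in either direction. The expected step is a number no higher from compound 2 to compound 3 (the limit leaves the size open). A reading at the limit of the assay is the likeliest outcome. For compound 3 the estimated value is 200000 nM, with an expected range from 80000 nM to 400000 nM.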

Compound 3, half-maximal inhibitory concentration: > 200000 nM
Compound 3: no number, only a limit; the forecaster's own chance of this, stated with the estimate: 75%; the middle value sits exactly at the limit.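

Compound 2 and compound 3 both end at a limit of the assay and give no number, so no step can be read between them. The compounds shown leave open whether acetyl in place of methyl on a saturated chain carbon bound to two saturated chain carbons has any effect.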